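From a Methylphenyl to a Nitrophenyl Piperazine Substituent

The source may report more compounds than this note shows. Statements on the series, on what has been measured and on what is new or still open speak of the compounds shown alone.

Measured compounds:
Compound 1, `O=C1Nc2ccc(Br)cc2/C1=N/NC(=S)N1CCN(c2ccccc2)CC1`: 10400 nM
Compound 2, `O=C1Nc2ccc(F)cc2/C1=N/NC(=S)N1CCN(c2ccccc2)CC1`: 12400 nM
Compound 3, `Cc1ccc(N2CCN(C(=S)N/N=C3\C(=O)Nc4ccc(Cl)cc43)CC2)cc1`: 6390 nM

All three compounds were tested in a functional assay on HCT-116 cells (Homo sapiens) for inhibition, read by MTT assay, with a stated time of 72 h; a lower number here means a stronger inhibitor, a higher number a weaker inhibitor. Within the data shown here, the only single-point comparison among them is a 1.2-fold higher number from compound 1 to compound 2 (0.08 log units; within the scatter), a halogen swap on the shared core. Compound 3 is not separated from compound 1 or from compound 2 by more than the scatter, so the three values are best regarded as one level.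

Compound 4, `O=C1Nc2ccc(Cl)cc2/C1=N/NC(=S)N1CCN(c2ccccc2[N+](=O)[O-])CC1`, keeps the chloro-bearing core of compound 3 and differs in one place: 2-nitrophenyl in place of 4-methylphenyl on an amine nitrogen in a ring. Among the measured compounds shown here, no measured step touches the group on the ring nitrogen; the one known step concerns the other aromatic ring and lies within the scatter, so it offers no guide to direction. With no evidence of movement anywhere in this set, compound 4 is expected to stay near compound 3, and the step from compound 3 is estimated as a 1.1-fold higher number from compound 3 to compound 4 (0.04 log units; within the scatter). The estimate for compound 4 in this assay is therefore 7000 nM, with a range from 2500 nM to 20000 nM.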

Compound 4, half-maximal inhibitory concentration: 4570 nM
Beside the measured number, compound 4's estimate is 1.5-fold (0.19 log units) above it; the measured number falls inside the stated range.
By their numbers in this assay, from the lowest: compounds 4, 3, 1 and 2 (each within the scatter of the next, the first and the last beyond it).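

Among the compounds shown, this is the only step that touches the group on the amine nitrogen in the six-membered ring, and in this assay it reads a 1.4-fold lower number from compound 3 to compound 4 (0.15 log units; within the scatter). Replacing 4-methylphenyl with 2-nitrophenyl adds hydrogen-bond acceptors and heavy atoms at this position, yet the two compounds remain on one level, so this exchange of aromatic groups gives no separation in this cell assay. No measurement is available that bears on the result.

The step changes both the substituent and its location on the phenyl ring, so the two cannot be told apart: 4-nitrophenyl and 2-methylphenyl would be needed to do that. From the compounds shown here alone, it also remains open whether a group of a different kind on this nitrogen, such as a benzyl group or a carboxylic acid-bearing phenyl, would move the number beyond the scatter.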